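This account rests on a few compounds, and the source may have more. Where it says the series, first, only, none or still open, it means among the compounds named here.

Compound 1 `COc1ccc2c(O[C@@H]3C[C@H]4C(=O)N[C@]5(C(=O)NS(=O)(=O)C6CC6)C[C@H]5/C=C\CCCCCNC(=O)N4C3)cc(-c3nc(C(C)C)cs3)nc2c1` sits in the middle of three measured compounds. In an ADME assay on Caco-2 cells (Homo sapiens) for permeability, in the apical to basolateral direction (on this read-out higher numbers stand for higher permeability and lower numbers for lower permeability), compound 1 gives 10 10^-6 cm/s. Compound 3 `COc1ccc2c(O[C@@H]3C[C@H]4C(=O)N[C@]5(C(=O)NS(=O)(=O)C6(C)CC6)C[C@H]5/C=C\CCCCCNC(=O)N4C3)cc(-c3nc(C(C)C)cs3)nc2c1`, which carries a methyl in place of hydrogen on a saturated ring carbon, gives 30 10^-6 cm/s in this assay, so that a 3.0-fold higher number from compound 1 to compound 3 (0.48 log units; beyond the scatter). Compound 2 `COc1ccc2c(O[C@@H]3C[C@H]4C(=O)N[C@]5(C(=O)NS(=O)(=O)C6CC6)C[C@H]5/C=C\CCCCNC(=O)N4C3)cc(-c3nc(C(C)C)cs3)nc2c1`, whose bridging chain is shorter by one link, gives 3 10^-6 cm/s in this assay, a lower number than compound 1.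

Compound 4 `COc1ccc2c(O[C@@H]3C[C@H]4C(=O)N[C@]5(C(=O)NS(=O)(=O)C6CC6)C[C@H]5/C=C\CCCCCNC(=O)N4C3)cc(-c3nc(C(C)C)cs3)nc2c1Cl` is not yet measured. It differs from compound 1 in one place: chloro in place of hydrogen on an aromatic carbon. Among the compounds with values here, none of the measured steps concerns a change of this kind. Within the data shown here, the only step with a known size, the methyl on a saturated ring carbon in the step from compound 1 to compound 3, touches a different part of the molecule and gives no guide to a chloro on an aromatic carbon. With nothing to build on, the expectation is that the step in this assay stays within the usual scatter, with a slight lean to a higher number. The estimated step is therefore a 1.3-fold higher number from compound 1 to compound 4 (0.11 log units; within the scatter). For compound 4 the expected value in this assay is 13 10^-6 cm/s, with a range from 5 10^-6 cm/s to 35 10^-6 cm/s.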

Compound 4, apparent permeability: 22 10^-6 cm/s
Estimate against measurement, compound 4: 1.7-fold (0.23 log units) below, and the stated range covers the measured number.
By their numbers in this assay, from the lowest: compound 2; then compound 1; then compounds 4 and 3 (each within the scatter of the next).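

Within the data shown here, the chloro sits on an aromatic carbon ortho to a methoxy group, and it is the first change on this aromatic ring that can be read in this assay: a 2.2-fold higher number from compound 1 to compound 4 (0.34 log units; beyond the scatter). This shows that this position can take a group larger than hydrogen with no loss on this read-out, and the number in fact goes up. Alongside a 3.0-fold higher number from compound 1 to compound 3 (0.48 log units; beyond the scatter), it also gives a second single change to compound 1, in a different part of the molecule, that raises the number beyond the scatter, though no measurement at hand gives a reason for either rise.

With only one group at this position, the compounds shown leave open whether a fluoro, a methyl, a nitrile, an amine or a carboxylic acid on the same aromatic carbon would move the number the same way as the chloro. They also leave open whether the chloro would have a similar effect in a molecule that carries the methyl on the saturated ring carbon of compound 3 or the shorter bridging chain of compound 2.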